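From methoxycarbonyl to benzyloxycarbonyl: expecting compound 3

A few compounds are considered here, and "the series" means these few. Any claim that something is new, unique, unknown or untested is made for them only; others in the source may bear on it.

Measured so far in a functional assay on NIH3T3 cells (Mus musculus) for inhibition, read by MTT assay, with a stated time of 72 h; on this read-out higher numbers stand for weaker inhibition and lower numbers for stronger inhibition:
Compound 1 `C=C1CC[C@H]2[C@@](C)(CC[C@@H](OC(C)=O)[C@@]2(C)C(=O)OCc2ccccc2)[C@@H]1CCC1=CCOC1=O` gives 12900 nM
Compound 2 `C=C1CC[C@H]2[C@@](C)(CC[C@@H](O)[C@@]2(C)C(=O)OC)[C@@H]1CCC1=CCOC1=O` gives 60600 nM

Compound 2 has the higher of the two numbers, and the gap to compound 1 lies beyond the scatter. Compound 3 `C=C1CC[C@H]2[C@@](C)(CC[C@@H](O)[C@@]2(C)C(=O)OCc2ccccc2)[C@@H]1CCC1=CCOC1=O` differs from compound 2 by phenyl in place of hydrogen on a saturated chain carbon bound to an oxygen next to a carbonyl group, or methoxycarbonyl to benzyloxycarbonyl. Among the compounds with values here, no measured pair isolates this change. Compound 1 also carries benzyloxycarbonyl and gives 12900 nM, so a moderate step to a lower number is expected in this assay. The expected step is a 2.8-fold lower number from compound 2 to compound 3 (0.44 log units; beyond the scatter). For compound 3 the estimated value is 22000 nM, with a range from 8000 nM to 60000 nM.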

Compound 3, half-maximal inhibitory concentration: 37900 nM
The estimate for compound 3 lay 1.7-fold (0.24 log units) below the measured number; measured number inside the range.
By their numbers in this assay, from the lowest: compound 1; then compounds 3 and 2 (each within the scatter of the next).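

In this assay, within the data shown here, phenyl in place of hydrogen on a saturated chain carbon bound to an oxygen next to a carbonyl group, read alone for the first time, gives a 1.6-fold lower number from compound 2 to compound 3 (0.20 log units; within the scatter), so methoxycarbonyl and benzyloxycarbonyl are not told apart here. Among these compounds, the one step beyond the scatter lies at the other site, where hydrogen in place of acetyl on an oxygen gives a 2.9-fold higher number from compound 1 to compound 3 (0.47 log units; beyond the scatter). Nothing measured here explains either step. From the compounds shown here alone, it remains open whether a carboxylic acid or an amide in place of these esters would move the number, and whether acetyl gives a comparable step on the methoxycarbonyl compound.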